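Naphthyl for Fluorophenyl on the Isoxazole of an Acid

The compounds below may be only part of what the source reports. "The series", "measured", "known", "first", "only" and "open" are said of these compounds alone.

Compound 1 `O=C(O)C1=Cc2ccccc2OC1(OCc1cc(-c2ccc(F)cc2)no1)C(F)(F)F` was tested in a functional assay on HeLa cells (Homo sapiens) for inhibition, read by MTT assay, with a stated time of 24 h; on this read-out higher numbers stand for weaker inhibition and lower numbers for stronger inhibition. In this assay compound 1 gives > 150000 nM, which is a limit of the assay and not a number. Compound 1 therefore sits at the limit of > 150000 nM in this assay, at which 1 of the 2 values shown sits. Compound 2 `CCOC(=O)C1=Cc2ccccc2OC1(OCc1cn(CC(=O)Nc2cccc(Cl)c2)nn1)C(F)(F)F` gives 12300 nM in this assay, but it differs from compound 1 in several places at once, so the two values only show what each compound does. Compound 3 `O=C(O)C1=Cc2ccccc2OC1(OCc1cc(-c2ccc3ccccc3c2)no1)C(F)(F)F` carries naphthalen-2-yl in place of 4-fluorophenyl on an aromatic carbon. Within the data shown here, with no comparable step measured, the expected step from compound 1 to compound 3 is an at least 1.5-fold lower number from compound 1 to compound 3 (0.17 log units; that floor lies within the scatter), toward somewhat stronger inhibition. Compound 3 is estimated at 100000 nM, within 30000 nM to 300000 nM.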

Compound 3, half-maximal inhibitory concentration: > 150000 nM
Compound 3: only a limit was reported; the forecaster's own chance of this, stated with the estimate: 50%; middle value at least 1.5-fold (0.17 log units) away from the limit.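

Compound 1 and compound 3 both stop at the same limit of this assay, so no step between them can be read: the limit of > 150000 nM in this assay, at which 2 of the 3 values shown sit.

On these data alone, whether naphthalen-2-yl in place of 4-fluorophenyl changes inhibition at all remains open.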